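Ring-nitrogen substituent on the shared core

A few compounds are considered here, and "the series" means these few. Any claim that something is new, unique, unknown or untested is made for them only; others in the source may bear on it.

Compound 1 `CCCCNc1nc(N)nc2c1CN(C)CC2` gives the lowest number of the three in an assay on HEK293 cells for agonist activity at Toll-like receptor 8 (Homo sapiens), read by a luciferase reporter, with a stated time of 6 h (on this read-out higher numbers stand for an effect only at larger amounts of compound and lower numbers for an effect already at smaller amounts), at 0.03 uM. Compound 2 `CCCCNc1nc(N)nc2c1CCN(C)C2` gives 0.2 uM and compound 3 `CCCCNc1nc(N)nc2c1CCN(C(=O)c1ccccc1)C2` gives 0.8 uM. The change from compound 1 to compound 4 `CCCCNc1nc(N)nc2c1CN(Cc1ccccc1Cl)CC2` is 2-chlorophenyl in place of hydrogen on a saturated chain carbon bound to an amine nitrogen in a ring. For the measured compounds named here, no measured pair shows this exact change; the nearest is a 4.0-fold higher number from compound 2 to compound 3 (0.60 log units; beyond the scatter), where the group on the ring amine nitrogen was likewise enlarged, on a related core. Enlarging that substituent once went with a modest higher number, so a step of similar size in the same direction is expected here, with wide uncertainty because the entering group differs from that of a 4.0-fold higher number from compound 2 to compound 3 (0.60 log units; beyond the scatter). Compound 4 is therefore expected to give 0.1 uM (range 0.03 uM to 0.4 uM), an estimated 3.3-fold higher number from compound 1 to compound 4 (0.52 log units; beyond the scatter).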

Compound 4, minimum effective concentration: 0.05 uM
Beside the measured number, compound 4's estimate is 2.0-fold (0.30 log units) above it, and the stated range covers the measured number.
By their numbers in this assay, from the lowest: compounds 1 and 4 (each within the scatter of the next); then compound 2; then compound 3.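

Working notes: at this position on the core of compound 1, methyl to 2-chlorobenzyl leaves the minimum effective concentration in this assay within the scatter (a 1.7-fold higher number from compound 1 to compound 4 (0.22 log units; within the scatter)). The ring amine nitrogen of this core therefore carries the added 2-chlorophenyl without a step beyond the scatter, unlike the benzoyl change on the related core (a 4.0-fold higher number from compound 2 to compound 3 (0.60 log units; beyond the scatter)). No available evidence accounts for this result.

Still open, on these data alone, is whether a plain benzyl or a longer chain such as phenethyl on this nitrogen would read the same way. As far as these compounds go, a benzyl carrying a carboxylic acid is equally open.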